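The source may report more compounds than this note shows. Statements on the series, on what has been measured and on what is new or still open speak of the compounds shown alone.

Compound 1 `CSc1ccc(Cc2nn(C(C)(C)C)c(=O)c3ccccc23)cc1` stands at the edge of what the measurements can show. In a functional assay on aorta with Alpha-1D adrenergic receptor (Rattus norvegicus) as the target (on this read-out lower numbers stand for an effect already at smaller amounts and higher numbers for an effect only at larger amounts of compound), compound 1 gives > 100000 nM, which is a limit of the assay rather than a number. Compound 2 `CCn1nc(Cc2ccc(SC)cc2)c2ccccc2c1=O` likewise returns a limit in this assay, > 100000 nM. Compound 3 `CSc1ccc(Cc2nn(-c3ccccc3)c(=O)c3ccccc23)cc1` also reaches only a limit in this assay, > 100000 nM. The three steps between these compounds, a step that the two limits leave unreadable from compound 1 to compound 2, a step that the two limits leave unreadable from compound 1 to compound 3 and a step that the two limits leave unreadable from compound 2 to compound 3, all change the group on the aromatic nitrogen, and their size is hidden by the limit of > 100000 nM in this assay, at which 3 of the 3 values shown sit. Compound 4 `CC(C)(C)n1nc(Cc2ccc(Cl)cc2)c2ccccc2c1=O` has not yet been measured. It differs from compound 1 at a different place: chloro in place of methylsulfanyl on an aromatic carbon. Going by the values given here, none of the measured steps touches this position, so the measured series says nothing about how this exchange is felt. What bears on it is only (the limit of > 100000 nM in this assay, at which 3 of the 3 values shown sit), since every measured member of the shared core sits there. The step that the limit leaves unreadable from compound 1 to compound 4 is therefore expected to be none beyond the scatter, with compound 4 most likely staying at the limit as well. Compound 4 is thus expected to give 150000 nM in this assay, within a range from 30000 nM to 1000000 nM.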

Compound 4, half-maximal effective concentration: > 100000 nM
Compound 4: only a limit was reported; the forecaster's own chance of this, stated with the estimate: 85%; the middle value does not contradict the limit.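

In this assay compound 4 gives > 100000 nM, which is a limit of the assay and not a number. Going by these compounds alone, compound 1 also stands at a limit, so no step between compound 1 and compound 4 can be read. The compounds shown leave open whether any exchange on the shared core would produce a measurable effect in this assay.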